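Replacing the nitro group of compound 1 with piperidin-1-yl

The compounds below may be only part of what the source reports. "The series", "measured", "known", "first", "only" and "open" are said of these compounds alone.

In a toxicity assay on Vero C1008 cells (Chlorocebus sabaeus) for cytotoxicity, read by MTT assay, with a stated time of 48 h (on this read-out higher numbers stand for lower toxicity in this test and lower numbers for higher toxicity in this test), compound 1 (`O=C(Nc1ccc([N+](=O)[O-])cc1)c1cc(Cl)ccc1O`) gives 2280 nM. Among the compounds with values here, the only other measured compound, compound 2 (`O=C(Nc1ccc([N+](=O)[O-])c(Cl)c1)c1cc(Cl)ccc1O`), gives 1510 nM. Within the data shown here, the difference is a 1.5-fold lower number from compound 1 to compound 2 (0.18 log units; within the scatter), so the two cannot be told apart, and compound 1 has no clear standing above or below its sole neighbour.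

Compound 3 (`O=C(Nc1ccc(N2CCCCC2)cc1)c1cc(Cl)ccc1O`) carries piperidin-1-yl in place of nitro on an aromatic carbon, para to a large group: piperidin-1-yl in place of nitro on an aromatic carbon. Among the measured compounds shown here, the one measured step, chloro in place of hydrogen on an aromatic carbon, bears on this only loosely. For the measured compounds named here, that step, a 1.5-fold lower number from compound 1 to compound 2 (0.18 log units; within the scatter), leaves the nitro group untouched, and no measured compound lacks it, so the data offer no direct guide to this exchange. Taking compound 1 at 2280 nM as the anchor, a modest move towards a higher number is expected, with a wide margin in either direction. The expected change is a 1.5-fold higher number from compound 1 to compound 3 (0.19 log units; within the scatter). Compound 3 is expected at 3500 nM, within an estimated range of 1000 nM to 12000 nM.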

Compound 3, half-maximal cytotoxic concentration: 65900 nM
Beside the measured number, compound 3's estimate is 19-fold (1.27 log units) below it; measured number outside the range, above it.
By their numbers in this assay, from the lowest: compounds 2 and 1 (each within the scatter of the next); then compound 3.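

In this assay, the exchange of nitro for piperidin-1-yl on an aromatic carbon, para to a large group, gives a 29-fold higher number from compound 1 to compound 3 (1.46 log units; beyond the scatter). This is the first step shown to lie beyond the scatter, whereas the chloro step, a 1.5-fold lower number from compound 1 to compound 2 (0.18 log units; within the scatter), does not, so the read-out proves sensitive to what occupies this position and toxicity in this test falls clearly with this exchange. The change removes nitro and brings in a six-membered non-aromatic ring with 1 hetero atom in a single move, and nothing available accounts for the size of the step.

As far as these compounds go, it remains open whether the step belongs to the ring itself, to its nitrogen attached to the aromatic carbon, or simply to the loss of nitro, a question that a morpholin-4-yl group, a dimethylamino group or a plain hydrogen at the same position could help to separate. From the compounds shown here alone, it is also open whether chloro in place of hydrogen would remain a small step on compound 3, where piperidin-1-yl rather than nitro stands at this position.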